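The source may hold more compounds than are shown below. What is called first, only, known or untested is meant among the compounds shown, and "the series" means these compounds.

In an assay on HEK293 cells for binding affinity to 5-hydroxytryptamine receptor 7 (Homo sapiens), read by radioligand binding, tested at 1 uM (on this read-out lower numbers stand for less inhibition and higher numbers for more inhibition at the one concentration tested (going by the name of the read-out)), compound 1 `CN1CCCN(CCn2ccc3ccc(N)cc32)CC1` gives 0%, compound 2 `CN1CCCN(CCn2ccc3ccc(C(N)=O)cc32)CC1` gives 33%, and compound 3 `CN1CCCN(CCn2ccc3ccc(OCc4ccccc4)cc32)CC1` gives 28%. Compound 3 thus stands second highest of the three numbers: the gap a number 5 percentage points lower from compound 2 to compound 3 (within the scatter) is within the scatter, whereas the gap a number 28 percentage points higher from compound 1 to compound 3 (beyond the scatter) lies beyond it. Compound 4 `C=C(C)c1ccc2ccn(CCN3CCCN(C)CC3)c2c1` differs from compound 3 by 1-methylethenyl in place of benzyloxy on an aromatic carbon. Among the compounds with values here, no measured step exchanges a benzyloxy for a 1-methylethenyl, so the only guide is that carbamoyl and benzyloxy on the same aromatic carbon gave similar numbers, and the change is expected to stay within the scatter, leaning slightly downward. Compound 4 is therefore expected to give 18%, in the range 0% to 40%, an expected step of a number 10 percentage points lower from compound 3 to compound 4 (within the scatter).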

Compound 4, a percentage reported as inhibition, at one concentration (the size of the read-out at that concentration, not a potency): 72%
For compound 4 the middle estimate is 54 percentage points below the measured one, and the stated range ends below it.
By their numbers in this assay, from the lowest: compound 1; then compounds 3 and 2 (each within the scatter of the next); then compound 4.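

Placing 1-methylethenyl on this aromatic carbon of the shared core in this assay gives a number 44 percentage points higher from compound 3 to compound 4 (beyond the scatter) and a number 39 percentage points higher from compound 2 to compound 4 (beyond the scatter) and a number 72 percentage points higher from compound 1 to compound 4 (beyond the scatter). The earlier similarity of carbamoyl and benzyloxy therefore marked no ceiling at this position, and a group with no ring and no hydrogen-bond acceptor exceeds all three earlier groups. Nothing available explains this rise. Going by these compounds, it stays open whether an isopropyl, a cyclopropyl or a chlorine here would hold the high number, and whether 1-methylethenyl would do the same on another aromatic carbon.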